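A few compounds are considered here, and "the series" means these few. Any claim that something is new, unique, unknown or untested is made for them only; others in the source may bear on it.

Measured in a functional assay on the whole organism with Rattus norvegicus as the target; a higher number here means that more compound is needed for the effect, a lower number that less compound is needed:
- compound 1, `CCOC(=O)C(=O)Nc1ccc(N(C)C)cc1C#N`: compound 1 gives 2.4 mg/kg
- compound 2, `CNc1cccc(NC(=O)C(=O)O)c1C#N`: compound 2 gives 0.07 mg/kg
- compound 3, `CCNc1cccc(NC(=O)C(=O)OCC)c1C#N`: compound 3 gives 0.03 mg/kg

Compound 3 stands at the lowest number of the three in this assay. Its nearest neighbour on the numbers is compound 2, whose value lies higher by a gap that goes beyond the scatter, and furthest from it is compound 1, whose value lies far higher. All three share a core bearing a cyano group, and compounds 2 and 3 both carry an alkylamino group on it, while compound 1 carries a dimethylamino group and gives the highest number.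

Compound 4, `CCOC(=O)C(=O)Nc1cccc(C(=O)OC)c1C#N`, has not yet been measured. It differs from compound 3 in one place: methoxycarbonyl in place of ethylamino on an aromatic carbon. The group that leaves carries one hydrogen-bond donor and the group that enters carries none, so compound 4 is the only one of the four without an amino substituent on the ring.

Among the measured compounds shown here, no measured pair shows this particular exchange. Taking the two lower numbers as tied to the alkylamino group, and the much higher number of compound 1 as a hint of how wide the range can be, a rise in the number is expected for compound 4, beyond the scatter, as the step of a 17-fold higher number from compound 3 to compound 4 (1.22 log units; beyond the scatter) states. Compound 4 is estimated at 0.5 mg/kg, with a range from 0.05 mg/kg to 5 mg/kg.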

Compound 4, dose for half-maximal effect: 0.8 mg/kg
For compound 4 the middle estimate is 1.6-fold (0.20 log units) below the measured one; measured number inside the range.
By their numbers in this assay, from the lowest: compound 3; then compound 2; then compound 4; then compound 1.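

In this assay, the exchange of ethylamino for methoxycarbonyl on an aromatic carbon ortho to a cyano group gives a 27-fold higher number from compound 3 to compound 4 (1.43 log units; beyond the scatter), a large step beyond the scatter. Among the compounds shown here, this is the first single-place change, so it is the first direct sign that the number responds to what this position carries, and that more compound is needed with methoxycarbonyl here than with ethylamino. The change swaps a group with 1 hydrogen-bond donor and 1 hydrogen-bond acceptor for one with 0 hydrogen-bond donors and 2 hydrogen-bond acceptors, but nothing available gives a cause for the rise.

From the compounds shown here alone, this single step cannot separate the loss of ethylamino from the arrival of methoxycarbonyl, so it remains open what a primary amine, a longer alkylamino chain, a methoxy group or a carboxylic acid on this aromatic carbon would give. Going by these compounds, it also remains open whether the same exchange would give a step of similar size if the ethyl ester elsewhere on the compound were replaced by a carboxylic acid.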